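From chloro to fluoro in a small halogen series

This account rests on a few compounds, and the source may have more. Where it says the series, first, only, none or still open, it means among the compounds named here.

In a physicochemical assay for lipophilicity (on this read-out lower numbers stand for lower lipophilicity and higher numbers for higher lipophilicity), compound 1 (`C[C@H]1CC[C@@H]2[C@@H](OC(=O)[C@]23CC(c2ccc(O)cc2)=NO3)[C@]2(C)C(=O)C=C[C@@]12O`) gives 0.932 as the lowest of the three readings. Compound 2 (`C[C@H]1CC[C@@H]2[C@@H](OC(=O)[C@]23CC(c2ccc(Br)cc2)N(c2ccccc2)O3)[C@]2(C)C(=O)C=C[C@@]12O`) gives 4 and compound 3 (`C[C@H]1CC[C@@H]2[C@@H](OC(=O)[C@]23CC(c2ccc(Cl)cc2)N(c2ccccc2)O3)[C@]2(C)C(=O)C=C[C@@]12O`) gives 3.87 on the same scale. Compound 3 therefore stands level with compound 2 within the scatter, and well beyond the scatter from compound 1.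

Compound 4 (`C[C@H]1CC[C@@H]2[C@@H](OC(=O)[C@]23CC(c2ccc(F)cc2)N(c2ccccc2)O3)[C@]2(C)C(=O)C=C[C@@]12O`) has not yet been measured. Its difference from compound 3 is fluoro in place of chloro on an aromatic carbon and it amounts to fluoro in place of chloro on an aromatic carbon, para to a large group. Cut one bond further out, this reads 4-chlorophenyl to 4-fluorophenyl.

Going by the values given here, only one measured step bears on this change, chloro in place of bromo on an aromatic carbon, which gave a number 0.13 log units lower from compound 2 to compound 3 (within the scatter) and so offers a weak hint of direction at most. Compound 1 differs in more than one place and gives no guide. A lower number is expected in this assay, with a step larger than that single small one, though this rests on thin evidence. The expected step is a number 0.42 log units lower from compound 3 to compound 4 (beyond the scatter) on this estimate.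

For compound 4 the estimated value is 3.45 with an expected range from 3.1 to 3.8 in this assay terms.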

Compound 4, partition coefficient: 3.35
Estimate against measurement, compound 4: 0.10 log units above; the range from low to high includes it.
By their numbers in this assay, from the lowest: compound 1; then compound 4; then compounds 3 and 2 (each within the scatter of the next).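

In this assay, the halogen on an aromatic carbon para to a large group now gives steps beyond the scatter: fluoro in place of chloro gives a number 0.52 log units lower from compound 3 to compound 4 (beyond the scatter), and fluoro in place of bromo gives a number 0.65 log units lower from compound 2 to compound 4 (beyond the scatter). The only earlier step at this position, chloro in place of bromo, gave a number 0.13 log units lower from compound 2 to compound 3 (within the scatter), so bromo and chloro remain level here and, among these three halogens, only fluoro separates from the others. Nothing available on these compounds bears on the reason for this separation.

The compounds shown leave open how a group other than a halogen at this position, such as an amine, a carboxylic acid or a methoxy group, would read in this assay, and whether any such group would fall nearer to the halogen set or well away from it. Compound 1 carries a hydroxy group on its aromatic ring but differs from the halogen compounds in more than one place, so it cannot answer that question.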